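Replacing the tetrazole tail with a carboxylic acid

The compounds below may be only part of what the source reports. "The series", "measured", "known", "first", "only" and "open" are said of these compounds alone.

Measured so far:
Compound 1 `CC(CCc1cccc(OCc2ccc3ccccc3n2)c1)Cc1nnn[nH]1` gives 17 nM
Compound 2 `CC(CCc1ccc(OCc2ccc3ccccc3n2)cc1)Cc1nnn[nH]1` gives 25 nM
Compound 3 `c1ccc2nc(COc3ccc(OCCCc4nnn[nH]4)cc3)ccc2c1` gives 69 nM

In an assay on membranes from lung (Cavia porcellus) for binding affinity to cysteinyl leukotriene receptor (Homo sapiens) (on this read-out higher numbers stand for weaker inhibition and lower numbers for stronger inhibition), compound 1 has the lowest of the three numbers. Compound 2 sits within the scatter of it, so the two cannot be ranked; compound 3, with 69 nM, lies beyond the scatter of compound 1, which gives 17 nM. The unmeasured compound 4 `O=C(O)CCCCc1cccc(OCc2ccc3ccccc3n2)c1` differs from compound 1 in one place: 2-carboxyethyl in place of 1-((1H-tetrazol-5-yl)methyl)ethyl on a saturated chain carbon, two bonds along the chain from an aromatic carbon. For the measured compounds named here, no measured pair shows this swap, so its effect can only be guessed. The author expects a modest rise in the number from compound 1 to compound 4 in this assay, a 2.4-fold higher number from compound 1 to compound 4 (0.37 log units; beyond the scatter), likely beyond the scatter but not large. Compound 4 is therefore estimated at 40 nM, within a range of 12 nM to 150 nM.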

Compound 4, inhibition constant: 100 nM
The estimate for compound 4 lay 2.5-fold (0.40 log units) below the measured number; the range from low to high includes it.
By their numbers in this assay, from the lowest: compounds 1 and 2 (each within the scatter of the next); then compounds 3 and 4 (each within the scatter of the next).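

In this assay, 2-carboxyethyl in place of 1-((1H-tetrazol-5-yl)methyl)ethyl gives a 5.9-fold higher number from compound 1 to compound 4 (0.77 log units; beyond the scatter) at this saturated chain carbon, the first step read at this position. The tail here is therefore not freely exchanged for this carboxylic acid. No measurement on these compounds accounts for the step.

As far as these compounds go, the swap changes both the end group and the chain carrying it, so the share of each remains open. A carboxylic acid on the methyl-branched chain of compound 1, or a tetrazole on the unbranched chain of compound 4, would separate them.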